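The source may report more compounds than this note shows. Statements on the series, on what has been measured and on what is new or still open speak of the compounds shown alone.

Working notes on a series sharing one core, each member carrying a heteroaryl group on the saturated chain carbon bound to the sulfur, tested in an assay on HEK293 cells for inhibition of sodium-dependent dopamine transporter (Homo sapiens), read by scintillation counting, with stated times of 5 min and 1 min; a lower number here means a stronger inhibitor, a higher number a weaker inhibitor. Compound 1 `Cc1noc(C[S+]([O-])C(c2ccccc2)c2ccccc2)n1` gives 56700 nM; compound 2 `Cc1nnc(C[S+]([O-])C(c2ccccc2)c2ccccc2)s1` is reported as "not active" (no number reported); compound 3 `[O-][S+](Cc1cc(C2CC2)on1)C(c1ccccc1)c1ccccc1` gives 38600 nM. For the measured compounds named here, compound 3 stands alongside compound 1, since their one step, a 1.5-fold lower number from compound 1 to compound 3 (0.17 log units; within the scatter), is within the scatter, and compound 2 offers no number to compare. Compound 4 `Cc1nc(O)cc(C[S+]([O-])C(c2ccccc2)c2ccccc2)n1` carries 6-hydroxy-2-methylpyrimidin-4-yl in place of 5-cyclopropyl-1,2-oxazol-3-yl on a saturated chain carbon bound to a sulfur. Going by the values given here, the only measured step bearing on such a heteroaryl exchange, a 1.5-fold lower number from compound 1 to compound 3 (0.17 log units; within the scatter), stayed within the scatter, while compound 2 shows that an exchange of this kind can also leave no measurable number. For compound 4 a step no larger than the scatter is expected, a 1.0-fold higher number from compound 3 to compound 4 (0.02 log units; within the scatter). Compound 4 is therefore estimated at 40000 nM, within 15000 nM to 120000 nM.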

Compound 4, half-maximal inhibitory concentration: 3100 nM
For compound 4 the middle estimate is 13-fold (1.11 log units) above the measured one; measured number below the stated range.
By their numbers in this assay, from the lowest: compound 4; then compounds 3 and 1 (each within the scatter of the next).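

The heteroaryl on the saturated chain carbon bound to a sulfur can move the number well beyond the scatter in this assay: 6-hydroxy-2-methylpyrimidin-4-yl gives a 12-fold lower number from compound 3 to compound 4 (1.10 log units; beyond the scatter) and an 18-fold lower number from compound 1 to compound 4 (1.26 log units; beyond the scatter). This exchange brings in a six-membered aromatic ring and 1 hydrogen-bond donor together, so the steps cannot be assigned to either change. No supporting data explain the size of these steps. On these data alone, whether the hydroxy group or the six-membered ring carries the step stays open, and an amine or a methoxy group in place of the hydroxy would bear on this.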